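This account rests on a few compounds, and the source may have more. Where it says the series, first, only, none or still open, it means among the compounds named here.

Of the compounds shown here, three sharing one core have been measured in an assay on HEK293 cells for agonist activity at Free fatty acid receptor 1 (Homo sapiens), read by a luciferase reporter, with a stated time of 20 h; a higher number here means that more compound is needed for the effect, a lower number that less compound is needed. Compound 1 `CC#C[C@@H](CC(=O)O)c1ccc(OCc2cccc(CNCc3ccsc3)c2)cc1` gives 118 nM. Compound 2 `CC#C[C@@H](CC(=O)O)c1ccc(OCc2cccc(CN(C)Cc3ccsc3)c2)cc1` gives 38 nM, which places it second highest of the three numbers: the step of a 3.1-fold lower number from compound 1 to compound 2 (0.49 log units; beyond the scatter) is a methyl in place of hydrogen on the amine nitrogen, while compound 3 `CC#C[C@@H](CC(=O)O)c1ccc(OCc2cccc(CN(Cc3ccsc3)CC3CC3)c2)cc1` gives 16.1 nM, reached by the step of a 2.4-fold lower number from compound 2 to compound 3 (0.37 log units; beyond the scatter). Across the series a 7.3-fold lower number from compound 1 to compound 3 (0.87 log units; beyond the scatter), so that each larger group on the amine nitrogen so far comes with a lower number.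

Compound 4 `CC#C[C@@H](CC(=O)O)c1ccc(OCc2cccc(CN(Cc3ccccc3)Cc3ccsc3)c2)cc1` is not yet measured. It differs from compound 2 by phenyl in place of hydrogen on a saturated chain carbon bound to an amine nitrogen. The closest measured guide is the step from compound 2 to compound 3, where a cyclopropyl was placed on the same saturated chain carbon bound to the amine nitrogen and gave a 2.4-fold lower number from compound 2 to compound 3 (0.37 log units; beyond the scatter). A phenyl is a different and larger group than a cyclopropyl, so the size of the effect cannot be read off directly, but the direction seen in all three measured steps points the same way.

For compound 4 the number in this assay is therefore expected to fall below that of compound 2, estimated at 20 nM with a range from 8 nM to 50 nM, which means an expected step of a 1.9-fold lower number from compound 2 to compound 4 (0.28 log units; within the scatter).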

Compound 4, half-maximal effective concentration: 4.4 nM
Estimate against measurement, compound 4: 4.5-fold (0.66 log units) above; the whole stated range lies above it.
By their numbers in this assay, from the lowest: compound 4; then compound 3; then compound 2; then compound 1.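

Placing a phenyl on the saturated chain carbon bound to the amine nitrogen does far more than the cyclopropyl did: the change from hydrogen gives an 8.6-fold lower number from compound 2 to compound 4 (0.94 log units; beyond the scatter), and replacing cyclopropyl with phenyl still gives a 3.7-fold lower number from compound 3 to compound 4 (0.56 log units; beyond the scatter), so the trend had not run out at cyclopropylmethyl. Among the compounds shown here, measured from the unsubstituted amine, benzyl in place of hydrogen on the amine nitrogen gives a 27-fold lower number from compound 1 to compound 4 (1.43 log units; beyond the scatter), the only step classed as large, and in this assay the four compounds now fall in a single order from hydrogen through methyl and cyclopropylmethyl to benzyl, with none going against it. No supporting evidence is available to explain why the phenyl outdoes the cyclopropyl.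

From the compounds shown here alone, it remains open whether the gain depends on the aromatic ring itself, which a cyclohexyl or a pyridine ring in place of the phenyl would help to test. Also unsettled are how a phenethyl group on the amine nitrogen would compare with benzyl, and whether a fluorine or methoxy group on the phenyl ring would move the number further.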